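Swapping thiophen-3-yl for thiophen-2-yl on a shared core

The source may hold more compounds than are shown below. What is called first, only, known or untested is meant among the compounds shown, and "the series" means these compounds.

In a functional assay on cells (Cancer cell lines, Homo sapiens) for inhibition (on this read-out lower numbers stand for stronger inhibition of growth and higher numbers for weaker inhibition of growth), compound 1 `Cc1cn2c(/C=N/NC(=N)N)c(-c3ccsc3)nc2s1` gives 20400 nM, and compound 2 `N=C(N)N/N=C/c1c(-c2ccsc2)nc2sccn12` gives 29500 nM. For the measured compounds named here, these two numbers lie within the scatter of each other, so compound 2 cannot be separated from the only other compound measured. The next compound, compound 3 `N=C(N)N/N=C/c1c(-c2cccs2)nc2sccn12`, has the same atoms as compound 2, joined differently: thiophen-2-yl in place of thiophen-3-yl on an aromatic carbon. In words, thiophen-2-yl stands in place of thiophen-3-yl on an aromatic carbon. Going by the values given here, no measured pair tests this swap directly. Among the compounds with values here, the one step available, a 1.4-fold higher number from compound 1 to compound 2 (0.16 log units; within the scatter), concerns a different change, hydrogen in place of methyl on an aromatic carbon, so it offers only indirect guidance. It does show that a single small change on this core stayed within the scatter. On that limited evidence, no step beyond the scatter is expected in this assay, and neither direction is favoured. The estimated step is a 1.1-fold lower number from compound 2 to compound 3 (0.04 log units; within the scatter). For compound 3 the estimated value is 27000 nM, with an expected range from 12000 nM to 60000 nM.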

Compound 3, concentration for total growth inhibition: 24000 nM
The estimate for compound 3 lay 1.1-fold (0.05 log units) above the measured number, and the stated range covers the measured number.
By their numbers in this assay, from the lowest: compounds 1, 3 and 2 (each within the scatter of the next).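

For the compounds shown here, the swap of thiophen-3-yl for thiophen-2-yl, on an aromatic carbon next to the ring nitrogen, comes with a 1.2-fold lower number from compound 2 to compound 3 (0.09 log units; within the scatter) in this assay and so gives the first direct reading at this position, since the earlier pair spoke only to hydrogen in place of methyl. Moving the point of attachment of the thiophene, with the heavy atoms and the counted donors and acceptors of the group unchanged, therefore gives no separation between compound 2 and compound 3 on this read-out, and the two attachments cannot be told apart here. Nothing available explains this result, and no independent measurement bears on it.

The compounds shown carry only thiophene at this position, so it remains open whether a different group there, such as phenyl, a pyridine ring, an amine or a carboxylic acid, would move the number beyond the scatter. Going by these compounds, it also remains open whether thiophen-2-yl would read the same with the methyl of compound 1 on the shared core, and whether any single change to this core can produce a step larger than the scatter in this assay at all.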